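The source may hold more compounds than are shown below. What is called first, only, known or untested is meant among the compounds shown, and "the series" means these compounds.

In a functional assay on HepG2 cells (Homo sapiens) for antiproliferative activity, read by CCK-8 assay, with a stated time of 48 h (a higher number here means a weaker inhibitor, a lower number a stronger inhibitor), compound 1 `O=C(NC1CCCCC1)c1cc(Oc2ccc(/C=C/c3ccccn3)cc2)ccn1` gives a half-maximal inhibitory concentration (20600 nM) within the scatter of compound 2 `CNC(=O)c1cc(Oc2ccc(/C=C/c3ccncc3)cc2)ccn1` (18200 nM). Compared with compound 2, compound 3 `O=C(NC1CCCCC1)c1cc(Oc2ccc(/C=C/c3ccncc3)cc2)ccn1` carries cyclohexyl in place of methyl on an amide-type nitrogen. Among the compounds with values here, no measured step isolates this change. Compound 1 also carries cyclohexyl on its amide-type nitrogen (20600 nM), so no step beyond the scatter is expected, in either direction. The estimated step (a 1.1-fold lower number from compound 2 to compound 3 (0.06 log units; within the scatter)) is therefore small. For compound 3 the estimated value is 16000 nM (expected range 6500 nM to 38000 nM).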

Compound 3, half-maximal inhibitory concentration: 22400 nM
Estimate against measurement, compound 3: 1.4-fold (0.15 log units) below; low and high end bracket the measured number.
By their numbers in this assay, from the lowest: compounds 2, 1 and 3 (each within the scatter of the next).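

In this assay, cyclohexyl in place of methyl on the amide-type nitrogen, with pyridin-4-yl kept, gives a 1.2-fold higher number from compound 2 to compound 3 (0.09 log units; within the scatter), so this swap does not separate the two compounds. With cyclohexyl kept, pyridin-4-yl in place of pyridin-2-yl gives a 1.1-fold higher number from compound 1 to compound 3 (0.04 log units; within the scatter), so neither single change moves the series beyond the scatter.

Still open, from the compounds shown here alone, is whether a carboxylic acid or a longer amine chain on the amide-type nitrogen would give a step beyond the scatter. No evidence bears on this flat result.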